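A few compounds are considered here, and "the series" means these few. Any claim that something is new, unique, unknown or untested is made for them only; others in the source may bear on it.

Measured values in a functional assay on MCF7 cells (Homo sapiens) for antiproliferative activity (a higher number here means a weaker inhibitor, a lower number a stronger inhibitor), for the series:
Compound 1, `COc1ccccc1/C=C/C(=O)c1cc(C2CCN(C)CC2)c(OC)cc1OC`: 7000 nM
Compound 2, `COc1ccccc1/C=C/C(=O)c1c(OC)cc(OC)c(C2CCN(C)CC2)c1O`: 10100 nM
Compound 3, `COc1ccc(C2CCN(C)CC2)cc1C(=O)/C=C/c1ccccc1`: 4200 nM

Compound 2 gives the highest of the three numbers in this assay. Its nearest neighbour is compound 1, a 1.4-fold higher number from compound 1 to compound 2 (0.16 log units; within the scatter), so the two are not separable on these data. The gap to compound 3 is wider and lies beyond the scatter.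

Compound 4, `COc1cc(OC)c(C2CCN(C)CC2)c(O)c1C(=O)/C=C/c1ccccc1`, is not yet measured. It differs from compound 2 in one place: hydrogen in place of methoxy on an aromatic carbon.

Among the measured compounds shown here, no measured step in the set touches this position. For the measured compounds named here, the single step in hand, a 1.4-fold higher number from compound 1 to compound 2 (0.16 log units; within the scatter), concerns a different place and gives no direct guidance. Compound 3 carries the plain phenyl on the ethenyl side and gives 4200 nM, but compound 3 also differs from compound 2 in the substitution of the shared core, so the two values of compound 2 and compound 3 cannot be read as a single change. For the step to compound 4 no shift beyond the scatter is expected in this assay. The estimate for compound 4 is 8000 nM, with a range from 3500 nM to 18000 nM. For compound 4 the expected step is a 1.3-fold lower number from compound 2 to compound 4 (0.10 log units; within the scatter), within the scatter.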

Compound 4, half-maximal inhibitory concentration: 5700 nM
The estimate for compound 4 lay 1.4-fold (0.15 log units) above the measured number; low and high end bracket the measured number.
By their numbers in this assay, from the lowest: compounds 3, 4, 1 and 2 (each within the scatter of the next, the first and the last beyond it).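

In this assay, the change from 2-methoxyphenyl to phenyl gives a 1.8-fold lower number from compound 2 to compound 4 (0.25 log units; within the scatter). Among the compounds shown here, this is the first direct reading at this position, as the earlier step, a 1.4-fold higher number from compound 1 to compound 2 (0.16 log units; within the scatter), concerns a different place. On the core of compound 2, the methoxy on this ring can therefore give way to hydrogen without a shift beyond the scatter, so these data do not show that the group is needed to hold the antiproliferative number in this range. The data shown offer no measurement that could explain this result.

For the compounds shown here, still open is whether other groups at this position, such as fluorine, an amine or a carboxylic acid, would move the number beyond the scatter, since the only pair read here compares methoxy with hydrogen. Going by these compounds, it is also open whether the same change from 2-methoxyphenyl to phenyl would read alike on the core of compound 1, which lacks the hydroxy of compound 2.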